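Acylsulfonamide in place of glycine amide on a shared core

The source may report more compounds than this note shows. Statements on the series, on what has been measured and on what is new or still open speak of the compounds shown alone.

Compound 1 `O=C(O)CNC(=O)c1ccc(C2CC2c2ccc(OCc3c(-c4c(Cl)cccc4Cl)noc3C3CC3)cc2Cl)cc1` was tested in an assay on isolated protein for agonist activity at Bile acid receptor (Homo sapiens), read by FRET (a higher number here means a larger maximal response, a lower number a smaller maximal response), and gave 100%. Compound 2 `O=C(O)c1ccc([C@H]2C[C@](O)(c3ccc(OCc4c(-c5c(Cl)cccc5Cl)noc4C4CC4)cc3Cl)C2)cc1`, which shares the core, gave 105% in this assay, and the two numbers lie within the usual scatter of each other, so neither stands apart. Compound 3 `CS(=O)(=O)NC(=O)c1ccc(C2CC2c2ccc(OCc3c(-c4c(Cl)cccc4Cl)noc3C3CC3)cc2Cl)cc1` has not yet been measured in this assay. Compared with compound 1 it carries methylsulfonyl in place of carboxymethyl on an amide-type nitrogen. Among the compounds with values here, no measured pair shows such a change, so the step is expected to be small, and compound 3 is estimated at 95% with a range from 70% to 120%, a step of a number 5 percentage points lower from compound 1 to compound 3 (within the scatter) that is expected to stay within the scatter.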

Compound 3, largest response reached (reported as efficacy), in percent of the reference or control that the assay uses: 100%
For compound 3 the middle estimate is 5 percentage points below the measured one; the measured number falls inside the stated range.
By their numbers in this assay, from the lowest: compounds 1, 3 and 2 (each within the scatter of the next).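

On the amide-type nitrogen of the shared core, methylsulfonyl takes the place of carboxymethyl in this assay with no change at the digits printed from compound 1 to compound 3 (within the scatter), so at this position the maximal response does not require the carboxymethyl group. This pair is the first among the compounds shown to test a change at this position, and it is a single example. Nothing measured here gives a reason for this outcome. From the compounds shown here alone, whether a longer chain, such as carboxyethyl, or an amine at this position would keep the response remains open. So does whether methylsulfonyl would behave the same way on the core of compound 2.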